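This account rests on a few compounds, and the source may have more. Where it says the series, first, only, none or still open, it means among the compounds named here.

Compound 1 `CN1CCN(CCCOc2cccc3nc(Nc4ccc(Cl)c(C(F)(F)F)c4)ccc23)CC1` gives 1720 nM
Compound 2 `CN1CCN(CCCOc2cccc3nc(Nc4ccc(Cl)c(F)c4)ccc23)CC1` gives 1910 nM
Compound 3 `CN1CCN(CCCOc2cccc3nc(Nc4cc(Cl)cc(Cl)c4)ccc23)CC1` gives 1840 nM
Compound 4 `CN1CCN(CCCOc2cccc3nc(Nc4cccc(Cl)c4)ccc23)CC1` is not yet measured

In a functional assay on NCI-H460 cells (Homo sapiens) for inhibition, read by sulforhodamine B assay, with a stated time of 48 h (on this read-out lower numbers stand for stronger inhibition of growth and higher numbers for weaker inhibition of growth), compound 2 gives 1910 nM and sits level with compounds 1 and 3, all three lying within the scatter of each other. The change leading to compound 4 is 3-chlorophenyl in place of 4-chloro-3-fluorophenyl on a nitrogen on an aromatic ring and amounts to 3-chlorophenyl in place of 4-chloro-3-fluorophenyl on a nitrogen on an aromatic ring. Going by the values given here, no measured step shows this exact change, but three steps alter the same group: the first (a 1.1-fold higher number from compound 1 to compound 2 (0.05 log units; within the scatter)), the second (a 1.1-fold higher number from compound 1 to compound 3 (0.03 log units; within the scatter)) and the third (a 1.0-fold lower number from compound 2 to compound 3 (0.02 log units; within the scatter)). All three stay within the scatter, so no step beyond the scatter is expected in this assay here. The estimated step is small (a 1.0-fold higher number from compound 2 to compound 4 (0.02 log units; within the scatter)). Compound 4 is expected at 2000 nM within a range of 1100 nM to 3600 nM as an estimate.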

Compound 4, concentration for 50% growth inhibition: 1870 nM
For compound 4 the middle estimate is 1.1-fold (0.03 log units) above the measured one, within the range that was stated.
By their numbers in this assay, from the lowest: compounds 1, 3, 4 and 2 (each within the scatter of the next).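

In this assay, the 3-chlorophenyl group on the nitrogen, with a single chloro on its ring, reads level with the more heavily substituted rings: a 1.0-fold lower number from compound 2 to compound 4 (0.01 log units; within the scatter) and a 1.0-fold higher number from compound 3 to compound 4 (0.01 log units; within the scatter) and a 1.1-fold higher number from compound 1 to compound 4 (0.04 log units; within the scatter). Among these four compounds, then, a second substituent on the phenyl ring, whether fluoro, chloro or trifluoromethyl, makes no readable difference to growth inhibition. No available evidence explains this flat result.

Still open, from the compounds shown here alone, is whether a plain phenyl group with no chloro would stay at this level. It is also unknown whether a methoxy group, a nitrile or a carboxylic acid on the ring would do so.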